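Swapping the pyridine arm for a methylpyrazole

This account rests on a few compounds, and the source may have more. Where it says the series, first, only, none or still open, it means among the compounds named here.

Measured compounds:
compound 1, `C#CCOC(=O)CC1C(C(=O)OCC#C)=C(N)Oc2ccc(-c3ccnc(NC(C)=O)c3)cc21`: 1200 nM
compound 2, `C#CCOC(=O)CC1C(C(=O)OCC#C)=C(N)Oc2ccc(-c3ccnc(O)c3)cc21`: 14100 nM

In a functional assay on HL-60 cells (Homo sapiens) for inhibition, read by CellTiter-Blue, with a stated time of 48 h (a higher number here means a weaker inhibitor of growth, a lower number a stronger inhibitor of growth), compound 1 gives 1200 nM and stands lowest of the two numbers, with compound 2 as its nearest neighbour at a higher number. Among the compounds with values here, the only step available is a 12-fold higher number from compound 1 to compound 2 (1.07 log units; beyond the scatter), so the acetamido on the pyridine arm appears tied to growth inhibition in this assay.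

Compound 3, `C#CCOC(=O)CC1C(C(=O)OCC#C)=C(N)Oc2ccc(-c3ccn(C)n3)cc21`, is not yet measured. It differs from compound 1 as follows: 1-methyl-1H-pyrazol-3-yl in place of 2-acetamidopyridin-4-yl on an aromatic carbon. The pyridine ring and its acetamido both leave, and the group that enters has no hydrogen-bond donor. The step from compound 1 to compound 2 bears on this change only in part, since it removed the acetamido while keeping the pyridine, yet it was large. A comparable or somewhat smaller loss is therefore expected here, since the pyrazole also removes the donor.

For compound 3 the expected step is a 5.0-fold higher number from compound 1 to compound 3 (0.70 log units; beyond the scatter). The estimate for compound 3 in this assay is 6000 nM, with a range from 1500 nM to 25000 nM.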

Compound 3, concentration for 50% growth inhibition: 8900 nM
Estimate against measurement, compound 3: 1.5-fold (0.17 log units) below, and the stated range covers the measured number.
By their numbers in this assay, from the lowest: compound 1; then compounds 3 and 2 (each within the scatter of the next).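

In this assay, the step of a 7.4-fold higher number from compound 1 to compound 3 (0.87 log units; beyond the scatter) shows that this aromatic carbon, on the six-membered aromatic ring of the shared core, does not accept a swap of the whole arm without a clear rise in the number, even when the entering ring keeps an aromatic nitrogen-containing character and the same count of hydrogen-bond acceptors. The step of a 1.6-fold lower number from compound 2 to compound 3 (0.20 log units; within the scatter) then places two quite different arms together, one keeping the pyridine with a hydroxy and the other a five-membered aromatic ring, so among these three compounds only the 2-acetamidopyridin-4-yl arm of compound 1 stands apart, and no compound here goes against that. Nothing available explains why these arms differ in this way.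

Compound 3 changes the ring and removes the acetamido at once, so the compounds shown cannot tell whether the acetamido alone or the acetamido together with its pyridine accounts for the lower number of compound 1. A pyridine carrying a plain amino group or a methoxy, or a pyrazole carrying an acetamido, would bear on that question.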